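The source may hold more compounds than are shown below. What is called first, only, known or untested is meant among the compounds shown, and "the series" means these compounds.

In a functional assay on DU-145 cells (Homo sapiens) for inhibition, read by trypan blue exclusion, with a stated time of 96 h (a higher number here means a weaker inhibitor of growth, a lower number a stronger inhibitor of growth), compound 1 `Cc1ccc(S(=O)(=O)/C(=C/c2ccc(Br)cc2)C(=O)c2ccc(Br)cc2)cc1` gives 10000 nM. Compound 2 `Cc1ccc(S(=O)(=O)/C(=C/c2ccc(F)cc2F)C(=O)c2ccc(Br)cc2)cc1` gives > 100000 nM, which is a limit of the assay and not a number. Compound 3 `CSc1ccc(/C=C(\C(=O)c2ccc(Br)cc2)S(=O)(=O)c2ccc(C)cc2)cc1` has yet to be measured, and the change leading to it is 4-(methylsulfanyl)phenyl in place of 2,4-difluorophenyl on a double-bonded chain carbon bound to a double-bonded chain carbon. For the measured compounds named here, only one measured step bears on this place, namely an at least 10-fold higher number from compound 1 to compound 2 (1.00 log units; beyond the scatter), made by 2,4-difluorophenyl replacing 4-bromophenyl. Compound 3 gives up the 2,4-difluorophenyl and, like compound 1 at 10000 nM, carries a single group at the 4 position of the ring, so a return towards that value is expected. The expected change is an at least 8.3-fold lower number from compound 2 to compound 3 (0.92 log units; beyond the scatter), a clear move to a lower number, though its size is only loosely estimated. For compound 3 the estimated value is 12000 nM, with an expected range from 2500 nM to 60000 nM.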

Compound 3, concentration for 50% growth inhibition: 1000 nM
Compound 3: the middle estimate sits 12-fold (1.08 log units) above what was measured; the whole stated range lies above it.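

In this assay, the ring on the double-bonded chain carbon proves able to do more than return to the level of compound 1: replacing bromo with methylsulfanyl on an aromatic carbon gives a 10-fold lower number from compound 1 to compound 3 (1.00 log units; beyond the scatter). Set against the 2,4-difluorophenyl group, the 4-(methylsulfanyl)phenyl group gives an at least 100-fold lower number from compound 2 to compound 3 (2.00 log units; beyond the scatter), so this one place spans a wide range of growth inhibition. The size of that larger step rests on compound 2, whose value is a limit of the assay and not a number: the limit of > 100000 nM in this assay, at which 1 of the 3 values shown sits.

As far as these compounds go, it remains open whether a methoxy group or an amine in place of methylsulfanyl on that aromatic carbon would hold this level. The compounds shown also do not separate the two fluorine atoms, so how a 4-fluorophenyl group in this place would compare remains unknown.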